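The source may report more compounds than this note shows. Statements on the series, on what has been measured and on what is new or still open speak of the compounds shown alone.

- Compound 1 `CCn1c(C(=O)Nc2cccc(C(F)(F)F)c2)ccc1C(CC)(CC)c1ccc(OCCC(O)(CC)CC)c(C)c1`: > 50000 nM (a limit)
- Compound 2 `CCn1c(C(=O)N(C)CC(=O)O)ccc1C(CC)(CC)c1ccc(OCCC(O)(CC)CC)c(C)c1`: 2740 nM

Within the data shown here, in a functional assay on Caco-2 cells (Homo sapiens) for antiproliferative activity, read by MTT assay, with a stated time of 48 h (a higher number here means a weaker inhibitor, a lower number a stronger inhibitor), compound 2 gives 2740 nM, the only actual number so far. Compound 1 gives only a limit, > 50000 nM.

Compound 3 `CCn1c(C(=O)NC(CC(=O)O)C(=O)OC)ccc1C(CC)(CC)c1ccc(OCCC(O)(CC)CC)c(C)c1` changes compound 2 on a carbonyl carbon: a group of 10 heavy atoms (5 carbon, 1 nitrogen, 4 oxygen; no ring) in place of a group of 6 heavy atoms (3 carbon, 1 nitrogen, 2 oxygen; no ring), on a carbonyl carbon. Among the measured compounds shown here, the one measured step at this place, an at least 18-fold lower number from compound 1 to compound 2 (1.26 log units; beyond the scatter), was large and removed a group with a ring. The group entering here has no ring either, so no repeat of that large step is expected.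

The expected change is a 1.5-fold higher number from compound 2 to compound 3 (0.16 log units; within the scatter), a small step that would stay within the scatter. The estimate for compound 3 is 4000 nM, with an expected range of 1000 nM to 20000 nM.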

Compound 3, half-maximal inhibitory concentration: 25200 nM
Beside the measured number, compound 3's estimate is 6.3-fold (0.80 log units) below it, outside the stated range (above it).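

The earlier step, an at least 18-fold lower number from compound 1 to compound 2 (1.26 log units; beyond the scatter), could be read as a matter of losing a ring, but this one shows that the position also responds to a change between ring-free groups: in this assay, the larger group gives a modest step, a 9.2-fold higher number from compound 2 to compound 3 (0.96 log units; beyond the scatter). Size and ring content therefore do not tell the whole story at this carbonyl carbon. The remaining step in this assay is an at least 1.9-fold lower number from compound 1 to compound 3 (0.29 log units; that floor lies within the scatter). That figure is only a floor, because compound 1 is known only as a limit: the limit of > 50000 nM in this assay, at which 1 of the 3 values shown sits.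

Which part of the larger group matters remains open. So does whether a dimethylamino group or a longer chain ending in a carboxylic acid would fall nearer compound 2 or compound 3.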